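Swapping the basic piperazine for a thienyl sulfide

The source may hold more compounds than are shown below. What is called first, only, known or untested is meant among the compounds shown, and "the series" means these compounds.

Compound 1 `CCN1CCN(C[C@H]2CN(c3ccc(-n4cc(-c5ccccn5)cn4)c(F)c3)C(=O)O2)CC1` gives 99 ug/mL in an ADME assay on L02 cells (Homo sapiens) for cytotoxicity, read by MTT assay, with a stated time of 48 h (on this read-out lower numbers stand for stronger inhibition and higher numbers for weaker inhibition), the lowest of the two numbers in hand. Compound 3 `O=C1O[C@@H](Cn2ccnc2)CN1c1ccc(-n2cc(-c3ccccn3)cn2)c(F)c1` gives 350 ug/mL in this assay. Compound 2 `CC(=O)OC[C@H]1CN(c2ccc(-n3cc(-c4ccccn4)cn3)c(F)c2)C(=O)O1` reaches only a limit in this assay, > 400 ug/mL (the limit of > 400 ug/mL in this assay, at which 1 of the 3 values shown sits). Both changes at this carbon raised the number: a 3.5-fold higher number from compound 1 to compound 3 (0.55 log units; beyond the scatter) and an at least 4.0-fold higher number from compound 1 to compound 2 (0.60 log units; beyond the scatter). Compound 4 `O=C1O[C@@H](CSc2cccs2)CN1c1ccc(-n2cc(-c3ccccn3)cn2)c(F)c1` carries (thiophen-2-yl)sulfanyl in place of 4-ethylpiperazin-1-yl on a saturated chain carbon bound to a saturated ring carbon. The two steps already measured at that position, one to a neutral ester and one to an azole, both ran upward and beyond the scatter, so the same direction is expected here. Compound 4 is expected to show a 2.5-fold higher number from compound 1 to compound 4 (0.40 log units; beyond the scatter). Compound 4 is accordingly estimated at 250 ug/mL, within a range from 100 ug/mL to 450 ug/mL.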

Compound 4, half-maximal inhibitory concentration: > 400 ug/mL
Compound 4 ended at the assay's limit (the forecaster's own chance of this, stated with the estimate: 30%); at least 1.6-fold (0.20 log units) between middle value and limit.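

Compound 4 brings a third replacement of the 4-ethylpiperazin-1-yl group, now by a (thiophen-2-yl)sulfanyl group containing carbon and sulfur but no nitrogen, and in this assay the number again rises, with an at least 4.0-fold higher number from compound 1 to compound 4 (0.60 log units; beyond the scatter). The sulfide cannot be separated from the imidazole, with an at least 1.1-fold higher number from compound 3 to compound 4 (0.05 log units; that floor lies within the scatter). Compound 4 ends at a limit, as does compound 2, so the step between them cannot be read: the limit of > 400 ug/mL in this assay, at which 2 of the 4 values shown sit.

On these data alone, whether the lower number of compound 1 belongs to the 4-ethylpiperazin-1-yl group alone or extends to other amines stays open. A dimethylamino or morpholin-4-yl group on the same carbon would address this.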